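A few compounds are considered here, and "the series" means these few. Any claim that something is new, unique, unknown or untested is made for them only; others in the source may bear on it.

Measured in a functional assay on CCRF-CEM cells (Homo sapiens) for inhibition, read by MTT assay, with a stated time of 72 h; a lower number here means a stronger inhibitor, a higher number a weaker inhibitor:
- Compound 1 `COc1cc(NC(C)CCCNC(=O)Nc2ccc(Br)cc2)c2ncccc2c1`: 23000 nM
- Compound 2 `COc1cc(NC(C)CCCNC(=O)Nc2ccc(F)cc2)c2ncccc2c1`: 26000 nM
- Compound 3 `COc1cc(NC(C)CCCNC(=O)Nc2cccc(C(F)(F)F)c2)c2ncccc2c1`: 19000 nM

Compound 3 stands level with the other two compounds, and all three steps among them are small: a 1.1-fold higher number from compound 1 to compound 2 (0.05 log units; within the scatter), a 1.2-fold lower number from compound 1 to compound 3 (0.08 log units; within the scatter) and a 1.4-fold lower number from compound 2 to compound 3 (0.14 log units; within the scatter). Compound 4 `COc1cc(NC(C)CCCNC(=O)NNC(=O)Nc2cccc(Cl)c2)c2ncccc2c1` carries ((3-chlorophenyl)carbamoyl)amino in place of 3-(trifluoromethyl)phenyl on an amide-type nitrogen. The measured steps only exchange one substituted phenyl group for another, so none of them tests this larger change, and that leaves the forecast uncertain. With no measured step beyond the scatter, none is expected here, and the expected step is a 1.1-fold higher number from compound 3 to compound 4 (0.02 log units; within the scatter). Compound 4 is estimated at 20000 nM, with an expected range of 8000 nM to 50000 nM.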

Compound 4, half-maximal inhibitory concentration: 81000 nM
Estimate against measurement, compound 4: 4.1-fold (0.61 log units) below; the whole stated range lies below it.
By their numbers in this assay, from the lowest: compounds 3, 1 and 2 (each within the scatter of the next); then compound 4.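

On this amide-type nitrogen, swapping one substituted phenyl group for another gave no step beyond the scatter, but ((3-chlorophenyl)carbamoyl)amino does give one in this assay (a 4.3-fold higher number from compound 3 to compound 4 (0.63 log units; beyond the scatter); a 3.1-fold higher number from compound 2 to compound 4 (0.49 log units; beyond the scatter); a 3.5-fold higher number from compound 1 to compound 4 (0.55 log units; beyond the scatter)). The position is therefore not indifferent to every change, and this larger group goes with a weaker inhibitor. Nothing available explains this shift.

The change alters both the linker and the ring substituent, so their shares stay unseparated. A plain 3-chlorophenyl group on this nitrogen would help separate them.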